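Trading Dimethylamino for Methyl on Two Related Cores

The compounds below may be only part of what the source reports. "The series", "measured", "known", "first", "only" and "open" are said of these compounds alone.

Compound 1 `Cc1ccc(N2C(=O)CS/C2=N\c2csc(-c3ccc(Cl)cc3)c2)cc1` and compound 2 `CN(C)c1ccc(N2C(=O)CS/C2=N\c2csc(-c3ccc(Cl)cc3)c2)cc1` share one core and differ only in the group on the aryl ring: methyl in place of dimethylamino on an aromatic carbon. In a functional assay on HT-29 cells (Homo sapiens) for cytotoxicity, read by MTT assay, with a stated time of 72 h (a lower number here means a stronger inhibitor, a higher number a weaker inhibitor), compound 1 gives 28900 nM, and compound 2 gives 29200 nM; the step of a 1.0-fold lower number from compound 2 to compound 1 (0.00 log units; within the scatter) is within the scatter. Compound 3 `CN(C)c1ccc(/C=C2\S/C(=N\c3nc(-c4ccc(Cl)cc4)cs3)NC2=O)cc1` is built on a different core, and the difference between the two cores is not broken down here. In this assay compound 3 gives 500 nM, the lowest of the three numbers. Compound 4 `Cc1ccc(/C=C2\S/C(=N\c3nc(-c4ccc(Cl)cc4)cs3)NC2=O)cc1` carries the same change on this second core: methyl in place of dimethylamino on an aromatic carbon. Because the measured step of a 1.0-fold lower number from compound 2 to compound 1 (0.00 log units; within the scatter) was flat, the step of a 1.2-fold higher number from compound 3 to compound 4 (0.08 log units; within the scatter) is expected to be small as well. Compound 4 is therefore estimated at 600 nM, with a likely range from 250 nM to 1500 nM.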

Compound 4, half-maximal inhibitory concentration: 500 nM
The estimate for compound 4 lay 1.2-fold (0.08 log units) above the measured number; measured number inside the range.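

Carried to the second core, the change from 4-(dimethylamino)phenyl to 4-methylphenyl gives no change at the digits printed from compound 3 to compound 4 (within the scatter) in this assay and so matches the flat step on the first core: the same change on two cores in this assay, a 1.0-fold lower number (0.00 log units; within the scatter) from compound 2 to compound 1 and no change at the digits printed (within the scatter) from compound 3 to compound 4, 1.0-fold (0.00 log units) apart, within the scatter of two such steps. Across these two pairs, then, the change transfers from one core to the other without a visible effect on the read-out. This does not show that it would stay flat on a third core, and it does not explain why the two cores sit so far apart in this assay.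

Going by these compounds, it remains open whether a carboxylic acid, a primary amine or a methoxy group in the same place would also leave the number unchanged. The 4-chlorophenyl group is held constant throughout, so replacing its chlorine with fluorine or a nitrile also remains an open question.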